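The source may report more compounds than this note shows. Statements on the series, on what has been measured and on what is new or still open speak of the compounds shown alone.

Compound 1 `Cc1ccc(OCC(=O)N(Cc2cccs2)C2CCCCC2)cc1`: in an assay on HEK293 cells for agonist activity at transient receptor potential cation channel subfamily M member 8 (Homo sapiens), read by fluorescence and calcium flux, with a stated time of 15 min (a higher number here means that more compound is needed for the effect, a lower number that less compound is needed), compound 1 gives 40000 nM.
Compound 2 `Cc1ccc(OCC(=O)N(Cc2cccs2)c2nccn2C)cc1`: compound 2 gives 1790 nM.

Compound 2 holds the lower of the two numbers; its nearest neighbour is compound 1, reached by a 22-fold lower number from compound 1 to compound 2 (1.35 log units; beyond the scatter), a large step. Compound 3 `Cc1ccc(OCC(=O)N(Cc2cccs2)c2ncccn2)cc1` differs from compound 2 by pyrimidin-2-yl in place of 1-methyl-1H-imidazol-2-yl on an amide-type nitrogen. That earlier step swapped a saturated ring for an aromatic one; here one aromatic ring with two hetero atoms replaces another, so it bears only loosely. Compound 3 is expected to stay near compound 2, with a 1.4-fold higher number from compound 2 to compound 3 (0.15 log units; within the scatter) within or barely beyond the scatter, estimated at 2500 nM (range 700 nM to 9000 nM).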

Compound 3, half-maximal effective concentration: 3700 nM
Compound 3: middle estimate off by 1.5-fold (0.17 log units), on the low side; measured number inside the range.
By their numbers in this assay, from the lowest: compound 2; then compound 3; then compound 1.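

At this amide-type nitrogen, the large drop seen on leaving cyclohexyl is not unique to 1-methyl-1H-imidazol-2-yl: in this assay there is also an 11-fold lower number from compound 1 to compound 3 (1.03 log units; beyond the scatter) with pyrimidin-2-yl in its place. The two aromatic rings are nevertheless not interchangeable, for all their matching counts of heavy atoms and hydrogen-bond acceptors, as the modest step of a 2.1-fold higher number from compound 2 to compound 3 (0.32 log units; beyond the scatter) shows when the five-membered ring gives way to the six-membered one. Nothing available explains this difference.

The compounds shown leave open whether a plain phenyl ring, with no ring nitrogen, would give a number close to those of compound 2 and compound 3. Also open, as far as these compounds go, is where pyridin-2-yl, with its single ring nitrogen, would fall.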